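A few compounds are considered here, and "the series" means these few. Any claim that something is new, unique, unknown or untested is made for them only; others in the source may bear on it.

Working notes on the series. The shared core carries a triazolylmethoxy arm ending in a substituted benzyl group. For the measured compounds named here, in a functional assay on QGY7701 cells (Homo sapiens) for cytotoxicity, read by MTT assay, with a stated time of 48 h (on this read-out higher numbers stand for weaker inhibition and lower numbers for stronger inhibition), compound 1 `O=c1ccoc2cc(OCc3cn(Cc4cccc(Br)c4)nn3)ccc12` gives 17600 nM, and compound 2 `O=c1ccoc2cc(OCc3cn(Cc4ccc(Br)cc4)nn3)ccc12` gives 96400 nM; the only measured step, a 5.5-fold higher number from compound 1 to compound 2 (0.74 log units; beyond the scatter), moves the bromo around the ring. On these two numbers compound 2 stands with the higher number. Compound 3 `COc1ccc(Cn2cc(COc3ccc4c(=O)ccoc4c3)nn2)cc1` differs from compound 2 by methoxy in place of bromo on an aromatic carbon. Going by the values given here, no measured step swaps bromo for another group, so that step gives only indirect guidance, and no step beyond the scatter is expected; the estimated step of a 1.4-fold lower number from compound 2 to compound 3 (0.14 log units; within the scatter) is therefore small. For compound 3 in this assay a value of 70000 nM is expected, within 20000 nM to 250000 nM.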

Compound 3, half-maximal inhibitory concentration: 56600 nM
The estimate for compound 3 lay 1.2-fold (0.09 log units) above the measured number; low and high end bracket the measured number.
By their numbers in this assay, from the lowest: compound 1; then compounds 3 and 2 (each within the scatter of the next).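

On the aromatic carbon para to a large group, in this assay, methoxy in place of bromo gives a 1.7-fold lower number from compound 2 to compound 3 (0.23 log units; within the scatter), so this swap does not separate the two compounds beyond the scatter. The other new step, a 3.2-fold higher number from compound 1 to compound 3 (0.51 log units; beyond the scatter), shows that the 4-methoxyphenyl arm, like the 4-bromophenyl arm, stands apart from the 3-bromophenyl arm of compound 1. No evidence on hand bears on this result. The compounds shown leave open whether an amine or a carboxylic acid on this carbon would read differently from bromo and methoxy. Going by these compounds, a 3-methoxyphenyl arm also remains open.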